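Removing the Benzyloxy Group from Compound 3

The source may report more compounds than this note shows. Statements on the series, on what has been measured and on what is new or still open speak of the compounds shown alone.

Compound 3 `O=C(NCc1ccc(OCc2ccccc2)cc1)[C@@H]1CCC(=O)N1Cc1ccccc1` has been measured in an assay on HEK293 cells for inhibition of Ataxin-2 (Mus musculus), read by fluorescence and Amplex Red; a higher number here means a weaker inhibitor, a lower number a stronger inhibitor. In this assay compound 3 gives > 5000 nM, which is a limit of the assay and not a number. Compound 1 `COC(=O)c1ccc(COc2ccc(CNC(=O)[C@@H]3CCC(=O)N3Cc3ccccc3)cc2)cc1` also gives a limit in this assay, > 5000 nM. Compound 2 `NS(=O)(=O)c1ccc(COc2ccc(CNC(=O)[C@@H]3CCC(=O)N3Cc3ccccc3)cc2)cc1` likewise gives a limit, > 5000 nM. All three values sit at the limit of > 5000 nM in this assay, at which 3 of the 3 values shown sit, so the steps a step that the two limits leave unreadable from compound 1 to compound 2, a step that the two limits leave unreadable from compound 1 to compound 3 and a step that the two limits leave unreadable from compound 2 to compound 3 cannot be read in size or direction.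

The step to compound 4 `O=C(NCc1ccccc1)[C@@H]1CCC(=O)N1Cc1ccccc1` is hydrogen in place of benzyloxy on an aromatic carbon. For the measured compounds named here, none of the measured steps removes the benzyloxy group itself; each of them exchanges a substituent carried on that group, and each is left unreadable by the two limits. There is therefore no measured step that sets a size or a direction for the change from compound 3 to compound 4 in this assay, and nothing shown suggests that the result will rise above the limit. The account expects compound 4 to remain at or near the limit, with an estimate of 10000 nM and a range from 3000 nM to 50000 nM. The step from compound 3 to compound 4 is estimated at a step that the limit leaves unreadable from compound 3 to compound 4, not readable beyond the scatter.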

Compound 4, half-maximal inhibitory concentration: > 5000 nM
Compound 4 gave a limit, no number; the forecaster's own chance of this, stated with the estimate: 85%; the middle value lies beyond the limit too.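

In this assay compound 4 gives > 5000 nM, which is a limit of the assay and not a number. Compound 3 also stands at a limit, so the change from compound 3 to compound 4 cannot be read in size or direction. The compounds shown leave open which change to the shared core, if any, would give a measurable value, as every value stays at one limit: the limit of > 5000 nM in this assay, at which 4 of the 4 values shown sit.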